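A few compounds are considered here, and "the series" means these few. Any claim that something is new, unique, unknown or untested is made for them only; others in the source may bear on it.

In an ADME assay on HEK293 cells (Homo sapiens) for cytotoxicity, read by MTT assay, with a stated time of 48 h (on this read-out lower numbers stand for stronger inhibition and higher numbers for weaker inhibition), compound 1 `C=C1CCC[C@]2(C)CCC(c3cn(-c4ccc(C(C)=O)cc4)nn3)=CC[C@@]12C` gives 520000 nM, and compound 2 `C=C1CCC[C@]2(C)CCC(c3cn(-c4cccc([N+](=O)[O-])c4)nn3)=CC[C@@]12C` gives 699000 nM. Within the data shown here, these two numbers lie within the usual scatter of each other, so compound 2 cannot be ranked against compound 1, the only other compound measured so far. Compound 3 `C=C1CCC[C@]2(C)CCC(c3cn(-c4ccc(I)cc4)nn3)=CC[C@@]12C` keeps the shared core and carries 4-iodophenyl in place of 3-nitrophenyl on an aromatic nitrogen. Among the measured compounds shown here, only one measured step bears on this change, since it alters the group at the same place: a 1.3-fold higher number from compound 1 to compound 2 (0.13 log units; within the scatter). For the measured compounds named here, that single step is small, but it is thin evidence, and no measured compound carries 4-iodophenyl. The expectation is therefore for no step beyond the scatter in this assay, and no direction can be favoured. The expected step is a 1.2-fold lower number from compound 2 to compound 3 (0.07 log units; within the scatter). For compound 3 the estimated value is 600000 nM, with an expected range from 250000 nM to 1200000 nM.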

Compound 3, half-maximal inhibitory concentration: 215000 nM
Estimate against measurement, compound 3: 2.8-fold (0.45 log units) above, outside the stated range (below it).
By their numbers in this assay, from the lowest: compound 3; then compounds 1 and 2 (each within the scatter of the next).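

In this assay, the group on the aromatic nitrogen can shift the read-out after all: 4-acetylphenyl and 3-nitrophenyl could not be told apart, but 4-iodophenyl gives a 3.3-fold lower number from compound 2 to compound 3 (0.51 log units; beyond the scatter) and also a 2.4-fold lower number from compound 1 to compound 3 (0.38 log units; beyond the scatter), and both steps are modest. Among these compounds, the second step is the easier one to read, as it exchanges only acetyl for iodo on an aromatic carbon, whereas the first exchanges a nitro group for iodo and also differs in the name's ring number, 3 against 4. Nothing measured here explains why the iodo compound gives the lowest number of the three, so no reason for the shift can be offered.

On these data alone, it remains open whether this shift belongs to iodine itself or would also appear with a chloro or bromo group on the phenyl ring, and whether an iodo group at the 3-position would behave like the one in 4-iodophenyl. How an amine or a carboxylic acid on that phenyl ring would compare with compound 3 also remains unanswered.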